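A few compounds are considered here, and "the series" means these few. Any claim that something is new, unique, unknown or untested is made for them only; others in the source may bear on it.

Of the compounds shown here, three sharing one core have been measured in a functional assay on CHO cells for antagonist activity at prostaglandin E2 receptor EP3 subtype (Homo sapiens), read by FLIPR, with a stated time of 1 h; on this read-out higher numbers stand for weaker inhibition and lower numbers for stronger inhibition. Compound 1 `CC1(c2ccc(-c3ccc4ccccc4c3)[nH]c2=O)OC(=O)NC1=O` gives 20 nM. Compound 2 `O=C1NC(=O)C(c2ccc(-c3ccc4ccccc4c3)[nH]c2=O)(C2CC2)O1` gives 50.1 nM. Compound 3 `CN1C(=O)OC(C)(c2ccc(-c3ccc4ccccc4c3)[nH]c2=O)C1=O` gives 501 nM, the highest of the three numbers: compound 3 sits a full order beyond compound 2 and further still beyond compound 1.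

Compound 4 `CC(C)N1C(=O)OC(C)(c2ccc(-c3ccc4ccccc4c3)[nH]c2=O)C1=O` carries the change (isopropyl in place of methyl on an amide-type nitrogen in a ring). Within the data shown here, two measured steps bear on it. The step of a 25-fold higher number from compound 1 to compound 3 (1.40 log units; beyond the scatter) shows that putting a group on that nitrogen costs a great deal. The step of a 2.5-fold higher number from compound 1 to compound 2 (0.40 log units; beyond the scatter) shows that a larger group in place of a methyl, there on a ring carbon, raises the number only modestly. Taken together, a larger group on the already substituted nitrogen is expected to raise the number further, by a step nearer the modest one than the large one. An upward step of a 3.0-fold higher number from compound 3 to compound 4 (0.48 log units; beyond the scatter) in this assay is therefore expected. Compound 4 is estimated at 1500 nM, within a range from 500 nM to 5000 nM.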

Compound 4, inhibition constant: 1580 nM
Compound 4: middle estimate off by 1.1-fold (0.02 log units), on the low side; the measured number falls inside the stated range.
By their numbers in this assay, from the lowest: compound 1; then compound 2; then compound 3; then compound 4.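

In this assay, isopropyl in place of methyl on the amide-type nitrogen in the ring gives a 3.2-fold higher number from compound 3 to compound 4 (0.50 log units; beyond the scatter), so the number keeps rising with the larger group once that nitrogen is substituted, though by a modest step. Measured from the amide hydrogen, isopropyl amounts to a 79-fold higher number from compound 1 to compound 4 (1.90 log units; beyond the scatter), and the greater part of that distance is already covered by the methyl of compound 3. Nothing available here accounts for either step.

The compounds shown carry only hydrogen, methyl or isopropyl on this nitrogen, so it remains open whether a longer chain, a cyclic group such as cyclopropyl, or a chain ending in an amine or a carboxylic acid would continue the same rise. Also open, going by these compounds, is how cyclopropyl on the ring carbon, as in compound 2, would combine with a group on the nitrogen.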